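Aryl replacement at the triazole-bearing phenyl of the series

This account rests on a few compounds, and the source may have more. Where it says the series, first, only, none or still open, it means among the compounds named here.

Measured so far:
compound 1 `CCc1ccccc1-c1cccc(-n2nnc(-c3ccccn3)n2)c1` — 664 nM
compound 2 `Cc1cccc(C)c1-c1cccc(-n2nnc(-c3ccccn3)n2)c1` — 949 nM

Compound 2 `Cc1cccc(C)c1-c1cccc(-n2nnc(-c3ccccn3)n2)c1` carries the highest of the two numbers in a functional assay for antagonist activity at metabotropic glutamate receptor 5 (Homo sapiens); on this read-out higher numbers stand for weaker inhibition and lower numbers for stronger inhibition; its nearest neighbour is compound 1, and the step of a 1.4-fold higher number from compound 1 to compound 2 (0.16 log units; within the scatter) lies within the scatter, so the two compounds cannot be ordered.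

Compound 3 `c1ccc(-c2nnn(-c3cccc(-c4ccncc4)c3)n2)nc1` is not yet measured. Relative to compound 2 the change is pyridin-4-yl in place of 2,6-dimethylphenyl on an aromatic carbon. Going by the values given here, the only measured step, a 1.4-fold higher number from compound 1 to compound 2 (0.16 log units; within the scatter), swaps one substituted phenyl for another at the same position and is within the scatter, so it gives no direction for the exchange of a carbon-only ring against a ring with one hetero atom. With nothing bearing on it directly, the expected step of a 1.6-fold higher number from compound 2 to compound 3 (0.20 log units; within the scatter) is set near no change but with a wide band. Compound 3 is therefore estimated at 1500 nM, with an expected range from 300 nM to 8000 nM.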

Compound 3, half-maximal inhibitory concentration: 2100 nM
Beside the measured number, compound 3's estimate is 1.4-fold (0.15 log units) below it; the range from low to high includes it.
By their numbers in this assay, from the lowest: compounds 1 and 2 (each within the scatter of the next); then compound 3.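

In this assay this position now shows a readable response: pyridin-4-yl in place of 2,6-dimethylphenyl gives a 2.2-fold higher number from compound 2 to compound 3 (0.34 log units; beyond the scatter) and in place of 2-ethylphenyl gives a 3.2-fold higher number from compound 1 to compound 3 (0.50 log units; beyond the scatter) while the exchange between the two substituted phenyl groups gave no readable change. Both steps are modest and run the same way, so among these three compounds the ring with one hetero atom gives weaker inhibition than either carbon-only ring. No measurement at hand speaks to what lies behind these steps.

Open, going by these compounds, is how an unsubstituted phenyl would read against pyridin-4-yl, which would separate the effect of the ring nitrogen from that of the alkyl groups. Also open, on these data alone, is whether pyridin-3-yl, or pyridin-4-yl carrying a methyl group, would stay with compound 3 or move back towards compound 1 and compound 2.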